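Bromo at a second indole position on the diterpene core

A few compounds are considered here, and "the series" means these few. Any claim that something is new, unique, unknown or untested is made for them only; others in the source may bear on it.

Compound 1 `COC(=O)[C@@]1(C)CCC=C2[C@@H]1CC[C@@H](C)[C@]2(C)Cc1c[nH]c2ccccc12` gives 3600 nM in a functional assay on HeLa cells (Homo sapiens) for inhibition, read by sulforhodamine B assay, with a stated time of 48 h; on this read-out lower numbers stand for stronger inhibition of growth and higher numbers for weaker inhibition of growth.
Compound 2 `COC(=O)[C@@]1(C)CCC=C2[C@@H]1CC[C@@H](C)[C@]2(C)Cc1c[nH]c2ccc(Br)cc12` gives 10000 nM in this assay.
Compound 3 `COC(=O)[C@@]1(C)CCC=C2[C@@H]1CC[C@@H](C)[C@]2(C)Cc1c[nH]c2ccc(OC)cc12` gives 1200 nM in this assay.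

Among these three numbers compound 1 stands second highest: compound 2 lies a 2.8-fold higher number from compound 1 to compound 2 (0.44 log units; beyond the scatter) and compound 3 lies a 3.0-fold lower number from compound 1 to compound 3 (0.48 log units; beyond the scatter), while compound 3 against compound 2 shows an 8.3-fold lower number from compound 2 to compound 3 (0.92 log units; beyond the scatter). Compound 4 `COC(=O)[C@@]1(C)CCC=C2[C@@H]1CC[C@@H](C)[C@]2(C)Cc1c[nH]c2c(Br)cccc12` differs from compound 1 by bromo in place of hydrogen on an aromatic carbon. For the measured compounds named here, the only measured step that bears on this is the one from compound 1 to compound 2, where bromo entered at another aromatic carbon of the same ring and gave a 2.8-fold higher number from compound 1 to compound 2 (0.44 log units; beyond the scatter). A step of similar modest size in the same direction is therefore expected in this assay, with more uncertainty for the new position; the expected step is a 1.9-fold higher number from compound 1 to compound 4 (0.29 log units; within the scatter). Compound 4 is estimated at 7000 nM, within 2500 nM to 20000 nM.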

Compound 4, concentration for 50% growth inhibition: 13000 nM
The estimate for compound 4 lay 1.9-fold (0.27 log units) below the measured number, within the range that was stated.
By their numbers in this assay, from the lowest: compound 3; then compound 1; then compounds 2 and 4 (each within the scatter of the next).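

In this assay bromo placed ortho to a fused ring and meta to a fused ring also gives weaker inhibition of growth, with a 3.6-fold higher number from compound 1 to compound 4 (0.56 log units; beyond the scatter), so the loss seen with compound 2 is not confined to one aromatic carbon. Compounds 2 and 4 lie within the scatter of each other, so these two bromo placements cannot be told apart. No measurement shown here accounts for the loss. As far as these compounds go, whether methoxy on this carbon would match the lower number of compound 3 remains open, as does the effect of an amine or a carboxylic acid there.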